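Replacing methylamino on the sulfonyl sulfur of compound 3

The source may report more compounds than this note shows. Statements on the series, on what has been measured and on what is new or still open speak of the compounds shown alone.

In a physicochemical assay for solubility, in phosphate buffer, measured as kinetic solubility, at pH 7.4, tested at 250 uM (on this read-out lower numbers stand for lower solubility and higher numbers for higher solubility), compound 3 (`CNS(=O)(=O)c1cc(C(=O)O)ccc1NCCCCCCCC(F)(F)F`) stands at 242000 nM and so level with compound 1 (`CCCCCCNc1ccc(C(=O)O)cc1S(=O)(=O)NC`) at 247000 nM while compound 2 (`CCCCCCCCNc1ccc(C(=O)O)cc1S(=O)(=O)NC`) lies lower at 53000 nM in this set. Compound 4 (`O=C(O)c1ccc(NCCCCCCCC(F)(F)F)c(S(=O)(=O)N2CCCC2)c1`) carries pyrrolidin-1-yl in place of methylamino on a sulfonyl sulfur. For the measured compounds named here, no measured step touches that place. The chain changes offer only indirect guidance, with a 4.7-fold lower number from compound 1 to compound 2 (0.67 log units; beyond the scatter) for ethyl in place of hydrogen, a 1.0-fold lower number from compound 1 to compound 3 (0.01 log units; within the scatter) for 2,2,2-trifluoroethyl in place of hydrogen and a 4.6-fold higher number from compound 2 to compound 3 (0.66 log units; beyond the scatter) for trifluoromethyl in place of methyl. Going by the size of the step to compound 2 (a 4.7-fold lower number from compound 1 to compound 2 (0.67 log units; beyond the scatter)), a modest move to a lower number is expected (a 2.2-fold lower number from compound 3 to compound 4 (0.34 log units; beyond the scatter)). For compound 4 the estimated value is 110000 nM (range 35000 nM to 245000 nM).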

Compound 4, solubility: 66000 nM
Compound 4: middle estimate off by 1.7-fold (0.22 log units), on the high side, and the stated range covers the measured number.
By their numbers in this assay, from the lowest: compounds 2 and 4 (each within the scatter of the next); then compounds 3 and 1 (each within the scatter of the next).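

In this assay the substituent on the sulfonyl sulfur proves able to shift the read-out, which until now had been seen to move only with changes in the chain: pyrrolidin-1-yl in place of methylamino gives a step beyond the scatter (a 3.7-fold lower number from compound 3 to compound 4 (0.56 log units; beyond the scatter)). This single change both removes the hydrogen-bond donor of methylamino and brings in a five-membered non-aromatic ring, so the two cannot be told apart here. Nothing measured explains the step. Dimethylamino on the sulfonyl sulfur would separate loss of the donor from the ring, while piperidin-1-yl would test ring size.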